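Working notes: the step from compound 2 to compound 4

The source may report more compounds than this note shows. Statements on the series, on what has been measured and on what is new or still open speak of the compounds shown alone.

Measured in an assay on isolated protein for inhibition of prostaglandin D2 receptor 2 (Homo sapiens), read by flow cytometry, with stated times of 15 min and 5 min; on this read-out higher numbers stand for weaker inhibition and lower numbers for stronger inhibition:
compound 1 `COc1ccc(CC(=O)O)cc1-c1ccc(C(F)(F)F)cc1CNC(=O)OCc1ccccc1` gives 709 nM
compound 2 `CCN(Cc1cc(C(F)(F)F)ccc1-c1cc(CC(=O)O)ccc1OC)C(=O)OCc1cc(F)cc(F)c1` gives 5 nM
compound 3 `COc1ccc(CC(=O)O)cc1-c1ccc(C(F)(F)F)cc1CN(C(=O)OCc1ccccc1)C1CCC1` gives 14 nM

Compound 2 holds the lowest number of the three; compound 3 stands nearest and compound 1 furthest, both gaps beyond the scatter. Among the compounds with values here, the only single-point step recorded, a 51-fold lower number from compound 1 to compound 3 (1.70 log units; beyond the scatter), concerns the substituent on the amide-type nitrogen and not the group on the saturated chain carbon bound to an oxygen next to a carbonyl group. Compound 4 `CCN(Cc1cc(C(F)(F)F)ccc1-c1cc(CC(=O)O)ccc1OC)C(=O)OCc1cccc(Cl)c1` differs from compound 2 exactly there: 3-chlorophenyl in place of 3,5-difluorophenyl on a saturated chain carbon bound to an oxygen next to a carbonyl group. Within the data shown here, no measured pair isolates a change in this part, so nothing in this assay bears directly on it; the expectation is a step no larger than the scatter, in either direction. Compound 4 is therefore estimated at 8 nM (range 3 nM to 25 nM), the expected step being a 1.6-fold higher number from compound 2 to compound 4 (0.20 log units; within the scatter).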

Compound 4, half-maximal inhibitory concentration: 7 nM
The estimate for compound 4 lay 1.1-fold (0.06 log units) above the measured number; measured number inside the range.
By their numbers in this assay, from the lowest: compounds 2, 4 and 3 (each within the scatter of the next, the first and the last beyond it); then compound 1.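

Within the data shown here, this is the first measured pair at this position. In this assay 3-chlorophenyl in place of 3,5-difluorophenyl gives a 1.4-fold higher number from compound 2 to compound 4 (0.15 log units; within the scatter), so the two groups cannot be told apart here and this position tolerates this exchange of halogens on the phenyl ring. No measurement available here explains this result.

Still open, as far as these compounds go, is whether a methoxy group or an amine on this phenyl ring, or a pyridine ring in its place, would read the same. Also open, from the compounds shown here alone, is whether 3-chlorophenyl and 3,5-difluorophenyl stay level when the nitrogen carries cyclobutyl.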